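The compounds below may be only part of what the source reports. "The series", "measured", "known", "first", "only" and "open" are said of these compounds alone.

In a functional assay on CHO cells for antagonist activity at prostaglandin D2 receptor (Mus musculus), read by cAMP accumulation and immunoassay, with a stated time of 10 min (on this read-out higher numbers stand for weaker inhibition and lower numbers for stronger inhibition), compound 1 `Cc1cc(OC[C@@H]2CN(C)c3ccccc3O2)cc(C)c1C(=O)Nc1cccc(CC(=O)O)c1` gives 3.5 nM, the lowest of the three numbers measured, though the gaps to the other two lie within the scatter. Compound 3 `Cc1cc(C(=O)Nc2cc(CC(=O)O)ccc2Cl)c(C)cc1OC[C@@H]1CN(C)c2ccccc2O1` gives 5.1 nM and compound 2 `Cc1ccc(CC(=O)O)cc1NC(=O)c1cc(C)c(OC[C@@H]2CN(C)c3ccccc3O2)cc1C` gives 5.7 nM, so the three stand together. Compound 4 `Cc1cc(OC[C@@H]2CN(C)c3ccccc3O2)cc(C)c1C(=O)Nc1cc(CC(=O)O)ccc1Cl` differs from compound 1 by chloro in place of hydrogen on an aromatic carbon. Going by the values given here, the one measured step that bears on this change is a 1.1-fold lower number from compound 2 to compound 3 (0.05 log units; within the scatter), where a chloro took the place of a methyl rather than of a hydrogen, and it left the number unchanged within the scatter. Compound 1 and compound 3 differ in more than one place, so their values speak only for themselves. A step no larger than the scatter is therefore expected in this assay, a 1.1-fold higher number from compound 1 to compound 4 (0.06 log units; within the scatter). For compound 4 the estimate is 4 nM, within 2 nM to 9 nM.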

Compound 4, half-maximal inhibitory concentration: 7.6 nM
Estimate against measurement, compound 4: 1.9-fold (0.28 log units) below; the measured number falls inside the stated range.
By their numbers in this assay, from the lowest: compounds 1, 3, 2 and 4 (each within the scatter of the next, the first and the last beyond it).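

In this assay, chloro in place of hydrogen, on the aromatic carbon para to a carboxymethyl group, gives a 2.2-fold higher number from compound 1 to compound 4 (0.34 log units; beyond the scatter) and so a modest step beyond the scatter. The earlier step, a 1.1-fold lower number from compound 2 to compound 3 (0.05 log units; within the scatter), only exchanged methyl for chloro at this position, whereas this one sets chloro against hydrogen there. No measurement shown here accounts for the step.

Going by these compounds, whether fluoro, methoxy or an amine at this position would move the number remains open, as does whether the step would recur on another core.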